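The source may hold more compounds than are shown below. What is called first, only, known or untested is meant among the compounds shown, and "the series" means these compounds.

Series notes. Compound 1 `CC(=O)c1cccc(NC(=O)Nc2ccc(OC(=O)c3cc4cc([N+](=O)[O-])ccc4s3)cc2)c1`, compound 2 `O=C(Nc1ccc(OC(=O)c2ccc(Cl)cc2)cc1)Nc1ccc(Cl)c(C(F)(F)F)c1` and compound 3 `COc1ccc(C(=O)Oc2ccc(NC(=O)Nc3ccc(Cl)c(C(F)(F)F)c3)cc2)cc1` share a diaryl urea core carrying an ester-linked aryl group. In a functional assay on A549 cells (Homo sapiens) for antiproliferative activity, read by MTT assay, with a stated time of 48 h (a higher number here means a weaker inhibitor, a lower number a stronger inhibitor), compound 1 gives 61500 nM, compound 2 gives 6620 nM and compound 3 gives 16100 nM, so compound 3 stands second highest of the three. For the measured compounds named here, the only single-point step measured so far, a 2.4-fold higher number from compound 2 to compound 3 (0.39 log units; beyond the scatter), touches the same ring. Compound 4 `O=C(Nc1ccc(OC(=O)c2ccccc2)cc1)Nc1ccc(Cl)c(C(F)(F)F)c1` differs from compound 3 by hydrogen in place of methoxy on an aromatic carbon. The chloro analogue compound 2 at 6620 nM and the methoxy analogue compound 3 at 16100 nM bracket a modest range, and the plain benzoyl is expected to land within it or near compound 3. The expected step for compound 4 is thus a 1.6-fold lower number from compound 3 to compound 4 (0.21 log units; within the scatter). Compound 4 is estimated at 10000 nM, range 4000 nM to 25000 nM.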

Compound 4, half-maximal inhibitory concentration: 30100 nM
Beside the measured number, compound 4's estimate is 3.0-fold (0.48 log units) below it, and the stated range ends below it.
By their numbers in this assay, from the lowest: compound 2; then compounds 3 and 4 (each within the scatter of the next); then compound 1.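

In this assay, going from methoxy to hydrogen on this aromatic carbon gives no resolved change (a 1.9-fold higher number from compound 3 to compound 4 (0.27 log units; within the scatter)), so methoxy and the unsubstituted benzoyl cannot be told apart here. Hydrogen in place of chloro does resolve (a 4.5-fold higher number from compound 2 to compound 4 (0.66 log units; beyond the scatter)), which leaves compound 2, the chloro analogue, as the only one of the three benzoyl variants that separates from the other two. On these data alone, whether a bromo, methyl or nitrile group on this carbon would read like chloro or like hydrogen stays open. No measurement available bears on why the chloro analogue stands apart.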